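A few compounds are considered here, and "the series" means these few. Any claim that something is new, unique, unknown or untested is made for them only; others in the source may bear on it.

Three related compounds have so far been tested in a functional assay on HCT-116 cells (Homo sapiens), read by crystal violet staining, with a stated time of 6 days; on this read-out lower numbers stand for stronger inhibition of growth and higher numbers for weaker inhibition of growth. Compound 1 `C/C=C/C(=O)Oc1cc(O)c2c(c1)O[C@H](c1ccc(OC)c(O)c1)CC2=O` gives 16900 nM in this assay. Compound 3 `CCCC(=O)Oc1cc(O)c2c(c1)O[C@H](c1ccc(OC)c(OC(=O)CCC)c1)CC2=O` gives 13200 nM, a number within the scatter of that of compound 1, so the two cannot be told apart. Compound 2 `COc1ccc([C@@H]2CC(=O)c3c(O)cc(OC(=O)c4ccccc4)cc3O2)cc1OC(=O)c1ccccc1` gives 46000 nM, a number beyond the scatter and higher than that of compound 1, so compound 1 holds the second highest of the three numbers.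

The unmeasured compound 4 `COc1ccc([C@@H]2CC(=O)c3c(O)cc(OC(=O)c4ccccc4C)cc3O2)cc1O` differs from compound 1 in one place: 2-methylphenyl in place of prop-1-en-1-yl on a carbonyl carbon. Among the measured compounds shown here, no pair of measured compounds differs in a single place, so the effect of this change cannot be read from a direct comparison. Compound 2, which carries aromatic groups on both of its carbonyl carbons, gives the highest number of the three, but it differs from compound 1 in two places, so its value is only a loose hint.

Compound 4 is expected to give about 21000 nM, with a range from 8000 nM to 55000 nM. The expected step of a 1.2-fold higher number from compound 1 to compound 4 (0.09 log units; within the scatter) is small, toward weaker inhibition if anything, and likely within the scatter.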

Compound 4, concentration for 50% growth inhibition: 22900 nM
Beside the measured number, compound 4's estimate is 1.1-fold (0.04 log units) below it; the range from low to high includes it.
By their numbers in this assay, from the lowest: compounds 3, 1, 4 and 2 (each within the scatter of the next, the first and the last beyond it).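

Among the compounds shown here, this is the first comparison here in which only one place changes, so the position can be read directly. In this assay the change from prop-1-en-1-yl to 2-methylphenyl on a carbonyl carbon gives a 1.4-fold higher number from compound 1 to compound 4 (0.13 log units; within the scatter) and cannot be told apart from no change at all. A group of seven carbons carrying an aromatic ring can therefore stand where a three-carbon open chain stood without a detectable shift in growth inhibition, though no measurement offered here explains this match.

The compounds shown leave open whether any group on this carbonyl carbon would move the number beyond the scatter, for example an amine or a carboxylic acid. They also leave open whether a longer chain would strengthen the inhibition of growth or weaken it.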